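The compounds below may be only part of what the source reports. "The series", "measured", "known", "first", "only" and "open" are said of these compounds alone.

Measured compounds:

Compound 1, `CCC(COc1ccc(Cl)cc1)OC(=O)NCc1ccccc1`: in an assay for inhibition of zeta-carotene desaturase, chloroplastic/chromoplastic (Capsicum annuum), using a Dixon plot, with a stated time of 8 h (a higher number here means a weaker inhibitor, a lower number a stronger inhibitor), compound 1 gives > 100000 nM, which is a limit of the assay and not a number.
Compound 2, `CCC(COc1cccc(C#N)c1)OC(=O)NCc1ccccc1`: in this assay compound 2 gives > 100000 nM, again a limit of the assay.
Compound 3, `CCOC(=O)c1cccc(OCC(CC)OC(=O)NCc2ccccc2)c1`: in this assay compound 3 gives > 100000 nM, also a limit of the assay.

Where compound 2 stands, then, is simply at the limit, with no number that would set it apart from the other two; all three values sit at the limit of > 100000 nM in this assay, at which 3 of the 3 values shown sit. The step that the two limits leave unreadable from compound 1 to compound 2 and the step that the two limits leave unreadable from compound 2 to compound 3 are therefore unreadable: two limits on either side give no size and no direction.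

The unmeasured compound 4, `CCC(COc1cccc(C(=O)O)c1)OC(=O)NCc1ccccc1`, differs from compound 2 in one place: carboxy in place of cyano on an aromatic carbon. Among the measured compounds shown here, both measured steps touch the substituent on this aromatic ring, and both are unreadable, so nothing so far gives a readable size for a change at this position. With every neighbour at the limit, the expectation for compound 4 in this assay is that the assay again reports only a limit, and the step that the limit leaves unreadable from compound 2 to compound 4 is estimated as none beyond the scatter. Compound 4 is estimated at 200000 nM in this assay, with a range from 30000 nM to 2000000 nM.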

Compound 4, half-maximal inhibitory concentration: > 100000 nM
Compound 4 gave a limit, no number (the forecaster's own chance of this, stated with the estimate: 85%); the middle value is on the limit's open side.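

In this assay compound 4 gives > 100000 nM, a limit of the assay and not a number. The steps from compound 2 and compound 3 to compound 4 therefore cannot be read, and all values stand at one point: the limit of > 100000 nM in this assay, at which 4 of the 4 values shown sit.

The compounds shown leave open whether any substituent on this aromatic ring separates these compounds in this assay.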